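The source may report more compounds than this note shows. Statements on the series, on what has been measured and on what is new or still open speak of the compounds shown alone.

In a functional assay on HepG2 cells (Homo sapiens) for antiproliferative activity, read by MTT assay, with a stated time of 48 h (a lower number here means a stronger inhibitor, a higher number a weaker inhibitor), compound 1 `O=C(Nc1ccccc1)Nc1cccc(CNc2nccnc2Cl)c1` gives 15600 nM and compound 2 `O=C(Nc1ccc(Cl)cc1)Nc1cccc(CNc2nccnc2Cl)c1` gives 8350 nM, and the comparison shows a 1.9-fold lower number from compound 1 to compound 2 (0.27 log units; within the scatter). Compound 3 `CN(C)c1ccc(NC(=O)Nc2cccc(CNc3nccnc3Cl)c2)cc1` gives > 40000 nM, which is a limit of the assay and not a number. The steps into it show an at least 2.5-fold higher number from compound 1 to compound 3 (0.40 log units; beyond the scatter) and an at least 4.7-fold higher number from compound 2 to compound 3 (0.68 log units; beyond the scatter). Compound 4 `CS(=O)(=O)c1ccc(NC(=O)Nc2cccc(CNc3nccnc3Cl)c2)cc1` carries methylsulfonyl in place of dimethylamino on an aromatic carbon. Among the measured compounds shown here, no measured step tests methylsulfonyl itself, but losing dimethylamino may undo the rise seen in an at least 2.5-fold higher number from compound 1 to compound 3 (0.40 log units; beyond the scatter). A clear drop in this assay is therefore expected, an estimated at least 2.6-fold lower number from compound 3 to compound 4 (0.42 log units; beyond the scatter). For compound 4 the estimated value is 15000 nM, with an expected range of 5000 nM to 40000 nM.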

Compound 4, half-maximal inhibitory concentration: 15100 nM
For compound 4 the middle estimate is 1.0-fold (0.00 log units) below the measured one; the measured number falls inside the stated range.
By their numbers in this assay, from the lowest: compounds 2, 4 and 1 (each within the scatter of the next). At a limit, above all of these: compound 3.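

In this assay, methylsulfonyl in place of dimethylamino gives an at least 2.6-fold lower number from compound 3 to compound 4 (0.42 log units; beyond the scatter), so the rise seen with dimethylamino does not extend to every group at this position. Methylsulfonyl also gives a 1.8-fold higher number from compound 2 to compound 4 (0.26 log units; within the scatter) and a 1.0-fold lower number from compound 1 to compound 4 (0.01 log units; within the scatter), so hydrogen, chloro and methylsulfonyl cannot be told apart here. Compound 3 stands at a limit, so the first step is only a bound: the limit of > 40000 nM in this assay, at which 1 of the 4 values shown sits.

From the compounds shown here alone, whether a carboxylic acid, a primary amine or a longer chain here would behave like dimethylamino or like the other three remains open. Also open, going by these compounds, is whether any group at this position can lower the number beyond the scatter.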